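Imidazoline to imidazole on the thioether sulfur

The source may report more compounds than this note shows. Statements on the series, on what has been measured and on what is new or still open speak of the compounds shown alone.

Working notes on a small set of thioethers in an assay on isolated protein for inhibition of Indoleamine 2,3-dioxygenase 1 (Homo sapiens), with a stated time of 60 min, tested at 10 uM; on this read-out lower numbers stand for less inhibition and higher numbers for more inhibition at the one concentration tested (going by the name of the read-out). Compound 1 `c1ccc(CCc2ccccc2CSC2=NCCN2)cc1` gives 17%, the second highest of the three numbers; compound 3 `Clc1ccc2sc(SCc3ccccc3CCc3ccccc3)nc2c1` with 9% lies within the scatter of it, whereas compound 2 `c1ccc(CCc2ccccc2CSc2nc3ccccc3[nH]2)cc1` with 43% stands beyond the scatter above it. For the measured compounds named here, no pair of these three differs in one place only, so no step can be read off. Compound 4 `c1ccc(CCc2ccccc2CSc2ncc[nH]2)cc1` differs from compound 1 as a group of 5 heavy atoms (3 carbon, 2 nitrogen; one five-membered aromatic ring with 2 hetero atoms) in place of a group of 5 heavy atoms (3 carbon, 2 nitrogen; one five-membered non-aromatic ring with 2 hetero atoms), on a sulfur. Going by the values given here, compound 2 is the one compound here that also carries a five-membered aromatic ring with 2 hetero atoms on the sulfur, and it shows the higher number. Among the compounds with values here, with no single-place step available, the expected step from compound 1 to compound 4 is a moderate rise, a number 13 percentage points higher from compound 1 to compound 4 (beyond the scatter). Compound 4 is therefore estimated at 30%, with a range of 12% to 48%.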

Compound 4, a percentage reported as inhibition, at one concentration (the size of the read-out at that concentration, not a potency): 19%
The estimate for compound 4 lay 11 percentage points above the measured number; the range from low to high includes it.
By their numbers in this assay, from the lowest: compounds 3, 1 and 4 (each within the scatter of the next); then compound 2.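

For the compounds shown here, the 1H-imidazol-2-yl group in place of the five-membered non-aromatic ring, on a sulfur, gives a number 2 percentage points higher from compound 1 to compound 4 (within the scatter) in this assay as the first single-place step. At this position, an aromatic ring and a non-aromatic ring with the same heavy-atom count therefore give numbers that cannot be told apart on this read-out. No measured evidence bears on this result.

On these data alone, whether a methyl group on the imidazole nitrogen would shift the number stays open. So does the effect of an amine or a carboxylic acid on that ring.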